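A few compounds are considered here, and "the series" means these few. Any claim that something is new, unique, unknown or untested is made for them only; others in the source may bear on it.

Compound 1 `O=c1[nH]c(=O)n([C@H]2C[C@H](O)[C@@H](CO)O2)cc1/C=N/O` and compound 2 `C=Cc1cn([C@H]2C[C@H](O)[C@@H](CO)O2)c(=O)[nH]c1=O` share one core and differ in a single group on an aromatic carbon. In an ADME assay on L1210/0 cells (Mus musculus) for cytotoxicity, with a stated time of 48 h (a higher number here means a weaker inhibitor, a lower number a stronger inhibitor), compound 1 gives 15500 nM and compound 2 gives 14200 nM. These two numbers lie within the usual scatter of each other, so compound 2 cannot be told apart from compound 1. Compound 3 `N#Cc1cn([C@H]2C[C@H](O)[C@@H](CO)O2)c(=O)[nH]c1=O` has cyano in place of vinyl on an aromatic carbon of compound 2 (cyano in place of vinyl on an aromatic carbon). Within the data shown here, only one measured step bears on this change: a 1.1-fold lower number from compound 1 to compound 2 (0.04 log units; within the scatter), also a swap of a small group on an aromatic carbon. It stayed within the scatter. Among the measured compounds shown here, no measured compound carries cyano, so this single step is thin evidence, and no shift beyond the scatter is expected in this assay. The estimated step is a 1.4-fold higher number from compound 2 to compound 3 (0.15 log units; within the scatter). For compound 3 the expected value is 20000 nM, within an estimated range from 6000 nM to 80000 nM.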

Compound 3, half-maximal inhibitory concentration: > 200000 nM
Compound 3 gave a limit, no number (the forecaster's own chance of this, stated with the estimate: 20%); at least 10-fold (1.00 log units) between middle value and limit.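

Compounds 1 and 2 could not be told apart in this assay, which made this aromatic carbon look tolerant of change, but cyano in place of vinyl gives an at least 14-fold higher number from compound 2 to compound 3 (1.14 log units; beyond the scatter), and the other comparison agrees, with an at least 12-fold higher number from compound 1 to compound 3 (1.11 log units; beyond the scatter). Vinyl and cyano each have 2 heavy atoms, so the large step appears without any change in that count, while the listed differences are a triple bond in place of a double bond and 1 hydrogen-bond acceptor in place of none. The reading for compound 3 is a limit of the assay, not a number: the limit of > 200000 nM in this assay, at which 1 of the 3 values shown sits.

The compounds shown cannot separate the triple bond from the hydrogen-bond acceptor as the source of the step, and the true size of the step stays unknown. From the compounds shown here alone, how an amine, a carboxylic acid or a longer chain on this aromatic carbon would read in this assay also stays open.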